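The source may hold more compounds than are shown below. What is called first, only, known or untested is meant among the compounds shown, and "the series" means these compounds.

In a functional assay on 786-0 cells (Homo sapiens) for inhibition, read by sulforhodamine B assay, with a stated time of 48 h, tested at 100 uM (a higher number here means a weaker effect of the compound at the concentration tested, a lower number a stronger effect), compound 1 `O=C(Nc1cccc(-n2cc(-c3ccncc3)c(-c3cc(O)cc(Cl)c3)n2)c1)Nc1ccc(Cl)c(Cl)c1` gives -58%. Compound 2 `COc1cc(Cl)cc(-c2nn(-c3cccc(NC(=O)Nc4ccc(Cl)c(Cl)c4)c3)cc2-c2ccncc2)c1` differs from compound 1 by methyl in place of hydrogen on an oxygen on an aromatic ring; in this assay compound 2 gives -46%, and that step is a number 12 percentage points higher from compound 1 to compound 2 (beyond the scatter). Among the measured compounds shown here, compound 2 thus stands at the higher of the two numbers measured so far, with compound 1 below it beyond the scatter. Compound 3 `COc1cc(Cl)cc(-c2nn(-c3cccc(NC(=O)c4cccc(C(F)(F)F)c4)c3)cc2-c2ccncc2)c1` is not yet measured; it differs from compound 2 by 3-(trifluoromethyl)phenyl in place of (3,4-dichlorophenyl)amino on a carbonyl carbon. For the measured compounds named here, no measured step touches this part of the molecule: the only step known concerns the oxygen substituent on a different ring, so it gives no guide to the size or direction of the change at the carbonyl carbon. The expectation for compound 3 therefore rests on compound 2 alone, with a wide range, and the expected step is a number 11 percentage points higher from compound 2 to compound 3 (beyond the scatter). Compound 3 is estimated at -35%, between -85% and 15%.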

Compound 3, a percentage reported as activity, at one concentration (the size of the read-out at that concentration, not a potency): 44%
For compound 3 the middle estimate is 79 percentage points below the measured one; measured number outside the range, above it.
By their numbers in this assay, from the lowest: compound 1; then compound 2; then compound 3.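

In this assay, the carbonyl carbon's substituent proves far more consequential than the oxygen substituent on the other ring: a number 90 percentage points higher from compound 2 to compound 3 (beyond the scatter), a large step against the modest a number 12 percentage points higher from compound 1 to compound 2 (beyond the scatter). The sign of the read-out also reverses, with compound 2 at -46% and compound 3 at 44%, so the effect at the concentration tested is much weaker after this single replacement. No measurement given here explains this change.

The replacement removes the amino nitrogen with its hydrogen-bond donor and also exchanges the two chlorines for a trifluoromethyl group, and these compounds cannot separate those changes. Open too, on these data alone, is how a (3-(trifluoromethyl)phenyl)amino group or a 3,4-dichlorophenyl group on the same carbonyl carbon would read, either of which would change only one of the two features.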